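Isopropoxy in place of fluoro: notes on the series

A few compounds are considered here, and "the series" means these few. Any claim that something is new, unique, unknown or untested is made for them only; others in the source may bear on it.

Values in an ADME assay on ECV-304 cells (Homo sapiens) for cytotoxicity, read by MTT assay, with a stated time of 72 h; a higher number here means a weaker inhibitor, a lower number a stronger inhibitor:
- Compound 1 `COc1ccc(C2=C(c3cc(OC)c(OC)c(OC)c3)C(=O)C(O)C2)cc1NC(=O)c1ccccc1`: > 100 ug/mL (a limit)
- Compound 2 `COc1ccc(C2=C(c3cc(OC)c(OC)c(OC)c3)C(=O)C(O)C2)cc1Cl`: 20 ug/mL
- Compound 3 `COc1ccc(C2=C(c3cc(OC)c(OC)c(OC)c3)C(=O)C(O)C2)cc1F`: 19.5 ug/mL

Compound 3 and compound 2 sit together, with a 1.0-fold lower number from compound 2 to compound 3 (0.01 log units; within the scatter). Compound 1 stands at a limit, (the limit of > 100 ug/mL in this assay, at which 1 of the 3 values shown sits).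

Compound 4 `COc1ccc(C2=C(c3cc(OC)c(OC)c(OC)c3)C(=O)C(O)C2)cc1OC(C)C` carries isopropoxy in place of fluoro on an aromatic carbon, ortho to a methoxy group (isopropoxy in place of fluoro on an aromatic carbon). The halogen exchange gives no guide to a change of this kind. The only measured departure from halogen at this place is benzamido in compound 1, with an at least 5.1-fold lower number from compound 1 to compound 3 (0.70 log units; beyond the scatter) and an at least 5.0-fold lower number from compound 1 to compound 2 (0.69 log units; beyond the scatter). A smaller move in the same direction is therefore expected, towards a higher number in this assay. The expected change is a 2.3-fold higher number from compound 3 to compound 4 (0.36 log units; beyond the scatter). For compound 4 the estimate is 45 ug/mL, with a range of 15 ug/mL to 100 ug/mL.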

Compound 4, half-maximal inhibitory concentration: > 100 ug/mL
Compound 4 was reported as a limit; the forecaster's own chance of this, stated with the estimate: 15%; middle value at least 2.2-fold (0.34 log units) from the limit.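

Exchanging halogen for isopropoxy, ortho to a methoxy group, gives an at least 5.1-fold higher number from compound 3 to compound 4 (0.70 log units; beyond the scatter) and an at least 5.0-fold higher number from compound 2 to compound 4 (0.69 log units; beyond the scatter) in this assay. Benzamido is therefore not the only non-halogen group at this position to end at the limit of the assay, and the halogen values of compound 2 and compound 3 do not extend to this ether. Compound 1 and compound 4 are both limits, so the step between them cannot be read: the limit of > 100 ug/mL in this assay, at which 2 of the 4 values shown sit.

Still open, as far as these compounds go, is whether a hydroxyl group, an amine or ethoxy at this position would stay with compound 2 and compound 3 or reach the limit.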